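The source may report more compounds than this note shows. Statements on the series, on what has been measured and on what is new or still open speak of the compounds shown alone.

The three measured compounds, all read in an assay on HEK293 cells for positive allosteric modulation of metabotropic glutamate receptor 2 (Rattus norvegicus), read by thallium flux, with a stated time of 2.5 min; a lower number here means that less compound is needed, a higher number that more compound is needed for the effect:
Compound 1, `Cc1c(OCCCCOc2ccc(C(=O)O)cc2Cl)ccc(C(=O)CC2CCCC2)c1O`, gives 237 nM.
Compound 2, `CC(=O)c1ccc(OCCCCOc2cccc(C(=O)O)c2C)c(C)c1O`, gives 200 nM.
Compound 3, `CC(=O)c1ccc(OCCCCOc2ccc(C(=O)O)cc2C)c(C)c1O`, gives 50 nM.

Among these, compound 1 has the highest number. Its nearest neighbour is compound 2, whose value lies within the usual scatter of repeat measurements, so the two cannot be ordered. Compound 3 stands clearly apart from compound 1, a gap beyond the scatter, so less of compound 3 is needed for the same effect.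

Compound 4, `Cc1c(OCCCCOc2ccc(C(=O)O)c(Cl)c2)ccc(C(=O)CC2CCCC2)c1O`, has not yet been measured in this assay. It holds the same atoms as compound 1, joined differently: 4-carboxy-3-chlorophenyl in place of 4-carboxy-2-chlorophenyl on an oxygen on a saturated carbon The rest of the molecule is unchanged.

For the measured compounds named here, no measured pair shows this exact change, so there is no step to lean on. Compound 2 gives 200 nM where compound 3 gives 50 nM, which shows that moving a group within this part of the molecule can shift the value beyond the scatter, but the direction for a chlorine is not fixed by anything measured here. The step of a 1.2-fold lower number from compound 1 to compound 4 (0.07 log units; within the scatter) is therefore expected to be small, likely no larger than the scatter, in either direction. Compound 4 is expected to give about 200 nM, within a range from 70 nM to 600 nM.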

Compound 4, half-maximal effective concentration: 510 nM
Beside the measured number, compound 4's estimate is 2.6-fold (0.41 log units) below it; the range from low to high includes it.
By their numbers in this assay, from the lowest: compound 3; then compounds 2 and 1 (each within the scatter of the next); then compound 4.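

In this assay, replacing 4-carboxy-2-chlorophenyl with 4-carboxy-3-chlorophenyl on an oxygen on a saturated carbon gives a 2.2-fold higher number from compound 1 to compound 4 (0.33 log units; beyond the scatter). The group that leaves and the group that enters hold the same atoms, so this pair isolates the placement of the chlorine on this ring, and it shows that the placement alone can carry the number past the usual scatter, though only modestly. It also gives this position a direction that no earlier pair differing in one place could supply: of these two arrangements, the 4-carboxy-2-chlorophenyl form in compound 1 needs less compound, while no measurement of any other property is at hand to account for the step.

A single pair cannot say whether a bromine atom or a methoxy group in place of the chlorine would follow the same direction, or whether a tetrazole in place of the carboxylic acid would keep it. Also open, going by these compounds, is whether moving the chlorine would shift the number by a similar amount if the other end of the molecule were changed.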